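A thiophen-2-yl in place of furan-2-yl

The compounds below may be only part of what the source reports. "The series", "measured", "known", "first", "only" and "open" are said of these compounds alone.

In a functional assay on HCT-116 cells (Homo sapiens), read by sulforhodamine B assay, with a stated time of 5 days (on this read-out lower numbers stand for stronger inhibition of growth and higher numbers for weaker inhibition of growth), three compounds have been measured so far.

Compound 1 `OC[C@H]1O[C@@H](n2cc(F)c3c(-c4cccs4)ncnc32)[C@H](O)[C@@H]1O`: 9 nM
Compound 2 `OC[C@H]1O[C@@H](n2cc(Cl)c3c(-c4ccccc4)ncnc32)[C@H](O)[C@@H]1O`: 1400 nM
Compound 3 `OC[C@H]1O[C@@H](n2cc(Cl)c3c(-c4ccco4)ncnc32)[C@H](O)[C@@H]1O`: > 10000 nM (a limit)

Compound 3 stands at the limit of > 10000 nM in this assay, at which 1 of the 3 values shown sits, and so has a limit and not a number. The next compound, compound 4 `OC[C@H]1O[C@@H](n2cc(Cl)c3c(-c4cccs4)ncnc32)[C@H](O)[C@@H]1O`, differs from it by thiophen-2-yl in place of furan-2-yl on an aromatic carbon, which is thiophen-2-yl in place of furan-2-yl on an aromatic carbon.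

One measured step acts at this same place. It is an at least 7.1-fold higher number from compound 2 to compound 3 (0.85 log units; beyond the scatter), with furan-2-yl in place of phenyl, and it lies beyond the scatter. It shows that the group at this place can change the read-out, but it does not test thiophen-2-yl. Compound 1 does carry thiophen-2-yl, with fluorine where compound 3 has chlorine, and compound 1 gives 9 nM in this assay. Among the measured compounds shown here, no measured step isolates that halogen, so this value is only a loose guide. Compound 2, the chlorine compound with phenyl, gives 1400 nM as its value. A move toward stronger inhibition of growth is therefore expected, and the estimated step is an at least 33-fold lower number from compound 3 to compound 4 (1.52 log units; beyond the scatter) by this reasoning. For compound 4 the estimate is 300 nM, with an expected range from 20 nM to 6000 nM as the likely span.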

Compound 4, concentration for 50% growth inhibition: 270 nM
Estimate against measurement, compound 4: 1.1-fold (0.05 log units) above, within the range that was stated.
By their numbers in this assay, from the lowest: compound 1; then compound 4; then compound 2. At a limit, above all of these: compound 3.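

With chlorine kept on the shared core, thiophen-2-yl and furan-2-yl are not interchangeable at this aromatic carbon, even though they have the same heavy-atom count and differ only in sulfur for oxygen, as an at least 37-fold lower number from compound 3 to compound 4 (1.56 log units; beyond the scatter) shows. Thiophen-2-yl also outdoes phenyl, with a 5.2-fold lower number from compound 2 to compound 4 (0.71 log units; beyond the scatter), so phenyl falls between the two five-membered rings and ring size alone does not order these three groups. Compound 3 has a limit and not a number, so the step from it gives only a lower bound on the size of the change: the limit of > 10000 nM in this assay, at which 1 of the 4 values shown sits. Among the compounds shown here, the thiophen-2-yl pair also isolates the halogen for the first time, with a 30-fold higher number from compound 1 to compound 4 (1.48 log units; beyond the scatter), so chloro in place of fluoro on the core matters about as much here as the largest change among the groups at this position.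

On these data alone, that halogen step is seen with thiophen-2-yl alone, and whether it holds with phenyl or furan-2-yl remains open. All the groups shown at this position are aromatic rings, so how an amine or a short alkyl chain there would read also remains open.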